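From Pyrrolidin-1-yl to Diethylamino at the Assay Limit

A few compounds are considered here, and "the series" means these few. Any claim that something is new, unique, unknown or untested is made for them only; others in the source may bear on it.

Among the compounds with values here, only two measurements are available so far, and neither gives an exact number. Compound 1 (`CCN(CC)CCNC(=O)CC(CC(=O)NC1Cc2ccccc2C1)c1ccccc1`) reads > 100000 nM in a functional assay on MCF7 cells (Homo sapiens) for inhibition (on this read-out lower numbers stand for stronger inhibition and higher numbers for weaker inhibition), and this value is a limit of the assay, not a number. Compound 2 (`CN(C(=O)CC(CC(=O)NCCN1CCCC1)c1ccccc1)C1Cc2ccccc2C1`) reads > 100000 nM in this assay and this value is likewise a limit. Within the data shown here, compound 2 therefore has no exact place on the scale, and the only other value shown is a limit too, so the two cannot be put in order.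

Compound 3 (`CCN(CC)CCNC(=O)CC(CC(=O)N(C)C1Cc2ccccc2C1)c1ccccc1`) differs from compound 2 in one place (diethylamino in place of pyrrolidin-1-yl on a saturated chain carbon, two bonds along the chain from an amide-type nitrogen). Diethylamino stands in place of pyrrolidin-1-yl on a saturated chain carbon, two bonds along the chain from an amide-type nitrogen. Among the measured compounds shown here, no measured step is available to show what such a swap does. With compound 2 at the limit of > 100000 nM as the starting point, no step beyond the scatter is expected in this assay in either direction. The expected change is small (a number no higher from compound 2 to compound 3 (the limit leaves the size open)) and remains only an estimate. The estimated value for compound 3 is 100000 nM (expected range 40000 nM to 250000 nM) and the assay may well report only a limit again.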

Compound 3, half-maximal inhibitory concentration: > 100000 nM
Compound 3 gave a limit, no number; the forecaster's own chance of this, stated with the estimate: 85%; the middle value sits exactly at the limit.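

Neither the swap from compound 2 to compound 3 nor the one from compound 1 to compound 3 gives a readable step in this assay, because all three compounds stop at the same assay limit, which is not a number: the limit of > 100000 nM in this assay, at which 3 of the 3 values shown sit.

Whether either swap changes inhibition at all, and how strongly any of these compounds inhibits, stays open.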